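Swapping the Aryl Cap of Compound 1 for Thiazolyl

A few compounds are considered here, and "the series" means these few. Any claim that something is new, unique, unknown or untested is made for them only; others in the source may bear on it.

This account follows a series of enol-dienone compounds that share one core and differ only in the aromatic group at the end of the double-bonded chain. Compound 1 `COC1=C(C)C(=O)/C(=C(O)/C=C/c2ccc(F)cc2)C(=O)C1(C)C` is the parent; in a functional assay on A-431 cells (Homo sapiens) for cytotoxicity (on this read-out lower numbers stand for an effect already at smaller amounts and higher numbers for an effect only at larger amounts of compound), compound 1 gives 4.1 ug/mL, the lowest of the three numbers measured. Compound 2 `COC1=C(C)C(=O)/C(=C(O)/C=C/c2ccc(C)cc2)C(=O)C1(C)C` gives 5.1 ug/mL, and the step of a 1.2-fold higher number from compound 1 to compound 2 (0.09 log units; within the scatter) lies within the scatter. Compound 3 `COC1=C(C)C(=O)/C(=C(O)/C=C/c2c(C)cc(C)cc2C)C(=O)C1(C)C` gives 20 ug/mL, a number beyond the scatter from compound 1.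

Compound 4 `COC1=C(C)C(=O)/C(=C(O)/C=C/c2nccs2)C(=O)C1(C)C` has not yet been measured. Its change from compound 1 is 1,3-thiazol-2-yl in place of 4-fluorophenyl on a double-bonded chain carbon bound to a double-bonded chain carbon. Among the compounds with values here, no measured step bears directly on replacing 4-fluorophenyl by a five-membered aromatic ring with 2 hetero atoms; the one single-point step, from compound 1 to compound 2, stayed within the scatter, and only the crowded trimethyl ring of compound 3 moved the number beyond it. Compound 4 is therefore expected to stay near compound 1, with an estimated step of a 1.5-fold higher number from compound 1 to compound 4 (0.17 log units; within the scatter). The estimate for compound 4 is 6 ug/mL, within a range from 2.5 ug/mL to 15 ug/mL.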

Compound 4, concentration for half-maximal effect: 6 ug/mL
Beside the measured number, compound 4's estimate shows no gap at the digits printed, within the range that was stated.
By their numbers in this assay, from the lowest: compounds 1, 2 and 4 (each within the scatter of the next); then compound 3.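

In this assay the step of a 1.5-fold higher number from compound 1 to compound 4 (0.17 log units; within the scatter) shows that, on a double-bonded chain carbon bound to a double-bonded chain carbon, the whole aromatic ring can change and not only a group on it: 1,3-thiazol-2-yl, a five-membered aromatic ring with 2 hetero atoms, takes the place of 4-fluorophenyl without leaving the scatter. The step of a 1.2-fold higher number from compound 2 to compound 4 (0.07 log units; within the scatter) reads the same way for 4-methylphenyl, so compound 4 cannot be told apart from either compound, even though it brings 2 hydrogen-bond acceptors where 4-fluorophenyl has 0. Nothing measured here bears on the reason for this result.

The compounds shown leave open whether other rings at this place, such as pyridin-2-yl or furan-2-yl, or an amine or a carboxylic acid on the thiazolyl ring, would keep the number within the scatter. Also open, on these data alone, is whether a longer chain leading to the 1,3-thiazol-2-yl ring would do the same.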